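Sulfonyl aryl swap from compound 2 to compound 3

The source may report more compounds than this note shows. Statements on the series, on what has been measured and on what is new or still open speak of the compounds shown alone.

Among the measured compounds shown here, in a functional assay on MDA-MB-231 cells (Homo sapiens) for inhibition, read by CellTiter-Glo, with a stated time of 72 h (a higher number here means that more compound is tolerated, a lower number that less compound is tolerated), compound 1 (`CC1=C(CC(=O)N(C)CCN(C)S(C)(=O)=O)c2cc(F)ccc2/C1=C\c1ccc([S+](C)[O-])cc1`) gives 12500 nM and compound 2 (`CC1=C(CC(=O)N(C)CCN(C)S(=O)(=O)c2ccc(C)cc2)c2cc(F)ccc2/C1=C\c1ccc([S+](C)[O-])cc1`) gives 17800 nM as the only two numbers so far. Compound 2 therefore stands level with compound 1 within the scatter, and neither can be ranked over the other.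

Compound 3 (`CC1=C(CC(=O)N(C)CCN(C)S(=O)(=O)c2ccc3ccccc3c2)c2cc(F)ccc2/C1=C\c1ccc([S+](C)[O-])cc1`) keeps the shared core of compound 2 and differs in one group, naphthalen-2-yl in place of 4-methylphenyl on a sulfonyl sulfur and nothing else changes.

For the measured compounds named here, only one measured step bears on this place, the exchange of methyl for 4-methylphenyl on the same sulfonyl sulfur, which gave a 1.4-fold higher number from compound 1 to compound 2 (0.15 log units; within the scatter) in this assay as its whole effect. Going by the values given here, no measured compound carries naphthalen-2-yl, so one step is thin ground and a shift in either direction remains open. Among the compounds with values here, no step beyond the scatter is expected in this assay because a 1.4-fold higher number from compound 1 to compound 2 (0.15 log units; within the scatter) is the only evidence at this place. The estimated step is a 1.2-fold lower number from compound 2 to compound 3 (0.07 log units; within the scatter) and no direction is favoured. Compound 3 is estimated at 15000 nM with 7000 nM to 30000 nM as the expected range.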

Compound 3, half-maximal cytotoxic concentration: 32100 nM
Compound 3: middle estimate off by 2.1-fold (0.33 log units), on the low side; the measured number lies above the stated range.
By their numbers in this assay, from the lowest: compounds 1, 2 and 3 (each within the scatter of the next, the first and the last beyond it).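

At the sulfonyl sulfur whose other neighbour is the sulfonamide nitrogen, the exchange of 4-methylphenyl for naphthalen-2-yl in this assay gives a 1.8-fold higher number from compound 2 to compound 3 (0.26 log units; within the scatter) and so does not separate the two aryl groups. Among the compounds shown here, the first step beyond the scatter at this position comes only over the larger exchange of methyl for naphthalen-2-yl, which gives a 2.6-fold higher number from compound 1 to compound 3 (0.41 log units; beyond the scatter) and remains modest in size. Among the methyl, 4-methylphenyl and naphthalen-2-yl groups, only the methyl and naphthalen-2-yl compounds can therefore be told apart, while compound 2 cannot be ranked against either compound 1 or compound 3.

No available measurement gives a reason for the step between compound 1 and compound 3 at this position. Still open, going by these compounds, is how this sulfonyl position would respond to a phenyl ring bearing an amine or a carboxylic acid, or to a longer alkyl chain, and whether any such group would lower the number in this assay rather than leave it level or raise it further.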